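The source may report more compounds than this note shows. Statements on the series, on what has been measured and on what is new or still open speak of the compounds shown alone.

In a functional assay on A-431 cells (Homo sapiens) for cytotoxicity (on this read-out higher numbers stand for an effect only at larger amounts of compound and lower numbers for an effect already at smaller amounts), compound 1 (`COC1=C(C)C(=O)/C(=C(O)/C=C/c2ccc(Br)cc2)C(=O)C1(C)C`) gives 9 ug/mL, compound 2 (`COC1=C(C)C(=O)/C(=C(O)/C=C/c2ccccc2C)C(=O)C1(C)C`) gives 5.2 ug/mL and compound 3 (`COC1=CC(O)=C(C(=O)/C=C/c2ccccc2)C(=O)C1(C)C`) gives 7 ug/mL. The value of compound 3 lies within the usual scatter of both others, so these three numbers cannot be ranked. Compound 4 (`CCC1=C(OC)C(C)(C)C(=O)C(C(=O)/C=C/c2ccccc2)=C1O`) differs from compound 3 by one change, ethyl in place of hydrogen on a double-bonded ring carbon.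

Among the compounds with values here, only one measured step is available as a guide, a 1.7-fold lower number from compound 1 to compound 2 (0.24 log units; within the scatter). It places 2-methylphenyl in place of 4-bromophenyl, away from the ring carbon that changes here, so it bears on this change only indirectly. It shows that one swap of a group left the number within the scatter. Within the data shown here, no measured step tests ethyl on this ring carbon, so the expectation is uncertain. The expected result in this assay is no shift beyond the scatter, and the estimated step is a 1.1-fold lower number from compound 3 to compound 4 (0.03 log units; within the scatter). For compound 4 the estimated value is 6.5 ug/mL, with an expected range from 3 ug/mL to 14 ug/mL.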

Compound 4, concentration for half-maximal effect: 13.8 ug/mL
Estimate against measurement, compound 4: 2.1-fold (0.33 log units) below, within the range that was stated.
By their numbers in this assay, from the lowest: compounds 2, 3, 1 and 4 (each within the scatter of the next, the first and the last beyond it).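

In this assay, within the data shown here, the swap of hydrogen for ethyl on this double-bonded ring carbon gives a 2.0-fold higher number from compound 3 to compound 4 (0.29 log units; within the scatter) and is the first measured step at this position, since the earlier step concerned the phenyl end of the chain. This ring carbon, which lies next to the ring atoms that bear the hydroxy and methoxy groups, can therefore carry ethyl, with its 2 heavy atoms, without a shift beyond the scatter. Nothing in the data explains the size of this step. 

On these data alone, a single group on this carbon says little about how others would behave, so a longer chain such as butyl, or a group of another kind such as an amine or a carboxylic acid, remains untested here. Whether this position stays this forgiving is therefore open.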